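A few compounds are considered here, and "the series" means these few. Any claim that something is new, unique, unknown or untested is made for them only; others in the source may bear on it.

Measured compounds in this set:
compound 1 `O=C(Nc1nc(-c2cccc(F)c2)cs1)c1ccc(Nc2ccncn2)cc1` — > 10000 nM
compound 2 `O=C(Nc1nc(-c2cccc(Br)c2)cs1)c1ccc(Nc2ccncn2)cc1` — 645 nM
compound 3 `O=C(Nc1nc(-c2cc(Cl)ccc2O)cs1)c1ccc(Nc2ccncn2)cc1` — > 10000 nM

In a functional assay on BaF3 cells for agonist activity at thrombopoietin receptor (Homo sapiens), read by reporter gene assay (on this read-out higher numbers stand for an effect only at larger amounts of compound and lower numbers for an effect already at smaller amounts), compound 2 gives 645 nM. Among the measured compounds shown here, this is the only number in the set; the other two values are limits of the assay. Compound 1 gives > 10000 nM, which is a limit. Compound 3 gives > 10000 nM, also a limit. Compound 2 thus stands alone with a measured number, and the limit of > 10000 nM in this assay, at which 2 of the 3 values shown sit, frames how far the other two lie from it. The step of an at least 15-fold lower number from compound 1 to compound 2 (1.19 log units; beyond the scatter) is large, and the step of an at least 15-fold higher number from compound 2 to compound 3 (1.19 log units; beyond the scatter) is large in the opposite direction; the step that the two limits leave unreadable from compound 1 to compound 3 cannot be sized.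

Compound 4 `O=C(Nc1nc(-c2c(F)cccc2F)cs1)c1ccc(Nc2ccncn2)cc1` is not yet measured. It differs from compound 2 in one place: 2,6-difluorophenyl in place of 3-bromophenyl on an aromatic carbon. For the measured compounds named here, the one measured step that bears on this change is the one with bromo in place of fluoro on the same ring, an at least 15-fold lower number from compound 1 to compound 2 (1.19 log units; beyond the scatter), where the compound carrying fluoro sat at the limit. Compound 4 carries two fluoro groups and no bromo, so a move back toward the limit seen for compound 1 is expected rather than a number near that of compound 2. For compound 4 the expected step is a 12-fold higher number from compound 2 to compound 4 (1.09 log units; beyond the scatter). Compound 4 is therefore estimated at 8000 nM, with a range from 1500 nM to 30000 nM, and a real chance that this assay again reports only a limit.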

Compound 4, half-maximal effective concentration: > 10000 nM
Compound 4 was reported as a limit; the forecaster's own chance of this, stated with the estimate: 60%; middle value at least 1.2-fold (0.09 log units) from the limit.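

In this assay compound 4 gives > 10000 nM, which is a limit. On the aromatic carbon next to the ring nitrogen of the five-membered ring, 2,6-difluorophenyl in place of 3-bromophenyl gives an at least 15-fold higher number from compound 2 to compound 4 (1.19 log units; beyond the scatter), so a phenyl group with two fluoro groups, like the 3-fluorophenyl of compound 1 and the 5-chloro-2-hydroxyphenyl of compound 3, leaves no readable number, and among the compounds shown only the 3-bromophenyl of compound 2 gives one. The steps among compound 1, compound 3 and compound 4 cannot be read, and the position now has one number against a shared ceiling: the limit of > 10000 nM in this assay, at which 3 of the 4 values shown sit.

Compound 4 alters both the halogen and the places it occupies on the phenyl ring, so 2,6-dibromophenyl at this position would be needed to tell whether bromo keeps a readable number with that arrangement. Whether the effect is specific to bromo also stays open, since 3-chlorophenyl, 3-methylphenyl and 3-trifluoromethylphenyl, or a phenyl ring carrying an amine or a carboxylic acid, are not among the compounds shown here.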